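Pyrrolidinyl for acetyl on the benzimidazole phenyl: a note

The compounds below may be only part of what the source reports. "The series", "measured", "known", "first", "only" and "open" are said of these compounds alone.

Two compounds of the series have been run in a functional assay for antagonist activity at Neuropeptides B/W receptor type 1 (Homo sapiens), read by cAMP accumulation; a higher number here means a weaker inhibitor, a lower number a stronger inhibitor. Compound 1 `O=[N+]([O-])c1ccc2nc(-c3ccccc3Cl)[nH]c2c1` gives 10700 nM. Compound 2 `CC(=O)c1cccc(-c2nc3cc([N+](=O)[O-])ccc3[nH]2)c1` returns only a limit of the assay, > 31600 nM, so no number is known for it; this is the limit of > 31600 nM in this assay, at which 1 of the 2 values shown sits, and it leaves compound 2 at the weak end of what has been measured. Compound 3 `O=[N+]([O-])c1ccc2[nH]c(-c3cccc(N4CCCC4)c3)nc2c1` differs from compound 2 by pyrrolidin-1-yl in place of acetyl on an aromatic carbon. Within the data shown here, no measured pair shows this change, so the size and direction of the step are open; with compound 2 at a limit, only a move toward a measurable value could show up at all. The step from compound 2 to compound 3 is expected to be about an at least 1.5-fold lower number from compound 2 to compound 3 (0.19 log units; that floor lies within the scatter), with the limit making its size uncertain. For compound 3 the estimate in this assay is 20000 nM, expected to lie between 4000 nM and 100000 nM.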

Compound 3, half-maximal inhibitory concentration: 6010 nM
Estimate against measurement, compound 3: 3.3-fold (0.52 log units) above; low and high end bracket the measured number.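

In this assay, pyrrolidin-1-yl in place of acetyl on an aromatic carbon, meta to a large group, takes the series from a limit to a measurable value and gives an at least 5.2-fold lower number from compound 2 to compound 3 (0.72 log units; beyond the scatter). Among these compounds, no earlier pair carried a change at this place, so this is the first evidence that the group held there can shift the read-out by more than the scatter. The true size of the step stays unknown because compound 2 has only a limit and no number: the limit of > 31600 nM in this assay, at which 1 of the 3 values shown sits.

Still open, on these data alone, is whether the lower number needs the pyrrolidin-1-yl ring itself, or whether an open-chain dimethylamino group or a piperidine ring at the same place would serve as well. Also open, as far as these compounds go, is how a carboxylic acid or a simple methoxy group would read there.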